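Replacing the pyrazole arm of compound 1 with a difluoropiperidine

The source may hold more compounds than are shown below. What is called first, only, known or untested is meant among the compounds shown, and "the series" means these compounds.

Measured compounds:
compound 1 `Cc1nn(CC(=O)N2CCN(c3sc(C(F)(F)F)nc3-c3nc4ccccc4[nH]3)C[C@H]2C)cc1CN(C)C` gives 2.7 nM in a functional assay on CHO-K1 cells for antagonist activity at C-X-C chemokine receptor type 3 (Homo sapiens), read by FLIPR, with a stated time of 10 min, in the presence of a further agent that is not named here; a lower number here means a stronger inhibitor, a higher number a weaker inhibitor
compound 2 `Cc1nc(C)n(CC(=O)N2CCN(c3sc(C(F)(F)F)nc3-c3nc4ccc(C5CCOCC5)cc4[nH]3)C[C@H]2C)n1` gives 3.3 nM in this assay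
compound 3 `C[C@@H]1CN(c2sc(C(F)(F)F)nc2-c2nc3cc(Cl)ccc3[nH]2)CCN1C(=O)Cn1cnc2cccnc21` gives 2.8 nM in this assay

Compound 1 carries the lowest number of the three, yet the gaps to compound 3 and to compound 2 both lie within the scatter of the method, so the three compounds cannot be placed in any order; all three share the same core and differ only in the group attached to the carbonyl-bearing chain and in the substitution of the fused ring.

Compound 4 `C[C@@H]1CN(c2sc(C(F)(F)F)nc2-c2nc3ccccc3[nH]2)CCN1C(=O)CN1CCC(F)(F)CC1` has not been measured. It differs from compound 1 in one place: 4,4-difluoropiperidin-1-yl in place of 4-((dimethylamino)methyl)-3-methyl-1H-pyrazol-1-yl on a saturated chain carbon bound to a carbonyl carbon. Within the data shown here, the measured compounds show that three quite different aromatic heterocycles at this position all give about the same number, but none of them carries a saturated ring there, so no comparable step is at hand.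

Compound 4 is therefore expected to remain close to compound 1, with a small loss as the more likely direction, giving a step of a 1.9-fold higher number from compound 1 to compound 4 (0.27 log units; within the scatter). The estimate for compound 4 is 5 nM, within a range from 1.5 nM to 20 nM.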

Compound 4, half-maximal inhibitory concentration: 15 nM
Compound 4: middle estimate off by 3.0-fold (0.48 log units), on the low side, and the stated range covers the measured number.
By their numbers in this assay, from the lowest: compounds 1, 3 and 2 (each within the scatter of the next); then compound 4.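

In this assay, among these compounds, 4,4-difluoropiperidin-1-yl in place of the pyrazole arm gives a 5.6-fold higher number from compound 1 to compound 4 (0.74 log units; beyond the scatter), the first step to lie beyond the scatter, so this position on a saturated chain carbon bound to a carbonyl carbon does respond to what it carries. The change replaces an aromatic five-membered ring bearing a dimethylaminomethyl group with a non-aromatic six-membered ring bearing fluorine, and it lowers the number of hydrogen-bond acceptors, so several features change in this single step. Nothing at hand shows which of these features accounts for the higher number.

A plain piperidine, or a piperidine carrying a dimethylaminomethyl group, would help separate the contributions of the fluorines, the ring and the amine. On these data alone, whether the difluoropiperidine behaves alike on a core with a chloro or tetrahydropyranyl substituent remains open.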